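The source may report more compounds than this note shows. Statements on the series, on what has been measured and on what is new or still open speak of the compounds shown alone.

In a physicochemical assay for solubility, read by chemiluminescence, measured as kinetic solubility (on this read-out lower numbers stand for lower solubility and higher numbers for higher solubility), three compounds sharing one core have been measured, and each reading is a limit of the assay rather than a number. Compound 1 `CC(=O)NCc1cccc(Cn2nc(NS(=O)(=O)c3ccc(Cl)s3)c3c(Cl)cccc32)c1` gives the limit >= 226 ug/mL. Compound 2 `CC(=O)NCc1cccc(Cn2nc(NS(=O)(=O)c3ccc(Cl)s3)c3c(O)cccc32)c1` gives the limit >= 166 ug/mL. Compound 3 `CC(=O)NCc1cccc(Cn2nc(NS(=O)(=O)c3ccc(Cl)s3)c3c(CO)cccc32)c1` gives the limit >= 113 ug/mL, so it has no exact value to start from. Compound 4 `CC(=O)NCc1cccc(Cn2nc(NS(=O)(=O)c3ccc(Cl)s3)c3c(C(C)(C)O)cccc32)c1` has 1-hydroxy-1-methylethyl in place of hydroxymethyl on an aromatic carbon. The measured changes at this carbon are a step that the two limits leave unreadable from compound 1 to compound 3 and a step that the two limits leave unreadable from compound 2 to compound 3, while the remaining one is a step that the two limits leave unreadable from compound 1 to compound 2. None of them offers a size to carry forward, so no change beyond the scatter is expected, in either direction. The expected step is a step that the limit leaves unreadable from compound 3 to compound 4. For compound 4, the estimate is 150 ug/mL, with an expected range of 60 ug/mL to 260 ug/mL.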

Compound 4, solubility: >= 159 ug/mL
Compound 4: only a limit was reported; the forecaster's own chance of this, stated with the estimate: 70%; middle value at least 1.0-fold (0.02 log units) away from the limit.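

Compound 4, like compound 1, compound 2 and compound 3, gives only a limit, and no step among these four compounds can be read. Going by these compounds, whether the groups at this aromatic carbon differ at all in solubility stays open.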